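Swapping the Sulfonyl Aryl Group: Nitrile to Fluorine

The source may report more compounds than this note shows. Statements on the series, on what has been measured and on what is new or still open speak of the compounds shown alone.

Compound 1 `CCN(CC)C(=O)CN(c1ccc(C)cc1)S(=O)(=O)c1ccc(OC)cc1` and compound 2 `CCN(CC)C(=O)CN(c1ccc(C)cc1)S(=O)(=O)c1ccc(C#N)cc1` share one core and differ only in the group carried on the sulfonyl ring. In a functional assay on CHO cells for inhibition of Orexin/Hypocretin receptor type 1 (Homo sapiens), read by FLIPR and calcium flux (a lower number here means a stronger inhibitor, a higher number a weaker inhibitor), compound 1 gives > 10000 nM, which is a limit of the assay rather than a number. Compound 2 gives > 10000 nM in this assay, again a limit and not a number. The change from compound 1 to compound 2, cyano in place of methoxy on an aromatic carbon, gives a step that the two limits leave unreadable from compound 1 to compound 2; its size cannot be read because of the limit of > 10000 nM in this assay, at which 2 of the 2 values shown sit.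

Compound 3 `CCN(CC)C(=O)CN(c1ccc(C)cc1)S(=O)(=O)c1ccccc1F` has not yet been measured. It differs from compound 2 as follows: 2-fluorophenyl in place of 4-cyanophenyl on a sulfonyl sulfur. Among the measured compounds shown here, the single measured step rests on two limits, so it tells nothing about size or direction, and no other step bears on this change. The expected step that the limit leaves unreadable from compound 2 to compound 3 is therefore none that can be read. Compound 3 is expected to sit at the limit as well. Compound 3 is estimated at 15000 nM in this assay, with a range from 3000 nM to 60000 nM.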

Compound 3, half-maximal inhibitory concentration: > 10000 nM
Compound 3 gave a limit, no number; the forecaster's own chance of this, stated with the estimate: 80%; the middle value does not contradict the limit.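

In this assay compound 3 gives > 10000 nM as well, which is again a limit of the assay and not a number. The steps from compound 1 and compound 2 to compound 3 cannot be read because all three values sit at one limit: (the limit of > 10000 nM in this assay, at which 3 of the 3 values shown sit). The compounds shown leave open how strongly, if at all, any of them inhibits this receptor.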